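Replacing a Methoxyphenyl Group with a Dichlorophenyl Group

The compounds below may be only part of what the source reports. "The series", "measured", "known", "first", "only" and "open" are said of these compounds alone.

Compounds measured in a functional assay on U-87MG ATCC cells (Homo sapiens) for cytotoxicity, read by MTT assay, with a stated time of 72 h; on this read-out lower numbers stand for stronger inhibition and higher numbers for weaker inhibition:
- compound 1 `COc1cccc(-c2cc(C(=O)Nc3ccc(Oc4ccnc5cc(OCCCN6CCCCC6)c(OC)cc45)c(F)c3)c3cc(F)ccc3n2)c1`: 1610 nM
- compound 2 `COc1cc2c(Oc3ccc(NC(=O)c4cc(-c5ccc(C)cc5)nc5ccc(F)cc45)cc3F)ccnc2cc1OCCCN1CCCCC1`: 1050 nM
- compound 3 `COc1ccc(-c2cc(C(=O)Nc3ccc(Oc4ccnc5cc(OCCCN6CCCCC6)c(OC)cc45)c(F)c3)c3cc(F)ccc3n2)cc1`: 1100 nM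

Compound 3 sits second highest of the three numbers, though all three lie within the scatter of one another. Compound 4 `COc1cc2c(Oc3ccc(NC(=O)c4cc(-c5ccc(Cl)cc5Cl)nc5ccc(F)cc45)cc3F)ccnc2cc1OCCCN1CCCCC1` differs from compound 3 by 2,4-dichlorophenyl in place of 4-methoxyphenyl on an aromatic carbon. Among the measured compounds shown here, no measured step swaps in a chlorine-bearing ring; the nearest precedents are a 1.5-fold lower number from compound 1 to compound 2 (0.19 log units; within the scatter), a 1.5-fold lower number from compound 1 to compound 3 (0.17 log units; within the scatter) and a 1.0-fold higher number from compound 2 to compound 3 (0.02 log units; within the scatter), each a change on the same ring and each within the scatter. On that basis the step from compound 3 to compound 4 is expected to be a 1.1-fold lower number from compound 3 to compound 4 (0.04 log units; within the scatter), no more than the scatter. Compound 4 is therefore estimated at 1000 nM, between 400 nM and 2800 nM.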

Compound 4, half-maximal inhibitory concentration: 1040 nM
For compound 4 the middle estimate is 1.0-fold (0.02 log units) below the measured one; measured number inside the range.
By their numbers in this assay, from the lowest: compounds 4, 2, 3 and 1 (each within the scatter of the next).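

In this assay the 2,4-dichlorophenyl group, on the carbon next to the ring nitrogen, gives a 1.1-fold lower number from compound 3 to compound 4 (0.02 log units; within the scatter) and a 1.0-fold lower number from compound 2 to compound 4 (0.00 log units; within the scatter) and also a 1.5-fold lower number from compound 1 to compound 4 (0.19 log units; within the scatter), so it cannot be told apart from the three earlier rings. At this position, then, the read-out stays within the scatter even when the ring loses its methoxy hydrogen-bond acceptor and gains chlorine. No measurement shown offers a reason for this sameness. Still open, going by these compounds, is whether a ring bearing an amine or a carboxylic acid would move the number beyond the scatter.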